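The source may hold more compounds than are shown below. What is called first, only, known or untested is meant among the compounds shown, and "the series" means these compounds.

In a functional assay on KB cells (Homo sapiens) for antiproliferative activity, read by MTT assay, with a stated time of 72 h, in the presence of a further agent that is not named here (on this read-out higher numbers stand for weaker inhibition and lower numbers for stronger inhibition), two compounds on a shared core have been measured. Compound 1 (`Nc1nc2[nH]c(CCSCCC(=O)NCc3ccccn3)cc2c(=O)[nH]1`) gives 8930 nM and compound 2 (`Nc1nc2[nH]c(CCSCC(=O)N[C@@H](CCC(=O)O)C(=O)O)cc2c(=O)[nH]1`) gives 373 nM on this scale. Compound 2 thus holds the lower of the two numbers, meaning the stronger inhibition of the pair, and the gap between them lies beyond the usual scatter. Compound 3 (`Nc1nc2[nH]c(CCSCC(=O)NCc3ccccn3)cc2c(=O)[nH]1`) departs from compound 2 at one place ((pyridin-2-yl)methyl in place of 1,3-dicarboxypropyl on an amide-type nitrogen): (pyridin-2-yl)methyl in place of 1,3-dicarboxypropyl on an amide-type nitrogen. Among the compounds with values here, no measured pair isolates this change. The nearest guide is compound 1, which carries the same (pyridin-2-yl)methyl on its amide-type nitrogen and gives 8930 nM even though its chain differs from that of compound 3. The step expected in this assay is therefore large, towards weaker inhibition and beyond the scatter: an estimated 16-fold higher number from compound 2 to compound 3 (1.21 log units; beyond the scatter) in all. Compound 3 is estimated at 6000 nM with an expected range of 1500 nM to 25000 nM in this measurement.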

Compound 3, half-maximal inhibitory concentration: 28400 nM
The estimate for compound 3 lay 4.7-fold (0.68 log units) below the measured number, and the stated range ends below it.
By their numbers in this assay, from the lowest: compound 2; then compound 1; then compound 3.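

In this assay, the change at the amide-type nitrogen can now be read on its own, with the chain on the shared core held the same: there is a 76-fold higher number from compound 2 to compound 3 (1.88 log units; beyond the scatter) when (pyridin-2-yl)methyl replaces 1,3-dicarboxypropyl. The earlier gap between compound 1 and compound 2 could not be assigned to this place, as those two compounds also differ in their chains, whereas this step shows that the group on this nitrogen alone can shift the number far beyond the scatter, with the stronger inhibition on the 1,3-dicarboxypropyl side. Nothing available here accounts for the size of this step.

As far as these compounds go, the step replaces the whole group at once, so it remains open how much of it follows the two carboxylic acids, the defined stereocentre or the pyridine ring; a carboxymethyl group with its single carboxylic acid, or a benzyl group, on the same nitrogen would help to separate these parts. From the compounds shown here alone, it also remains open how 1,3-dicarboxypropyl would read on the longer chain of compound 1.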